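The source may report more compounds than this note shows. Statements on the series, on what has been measured and on what is new or still open speak of the compounds shown alone.

Three compounds share one core and differ only in the group on a saturated ring carbon. Compound 1 `COc1cc(C2=NN(C(C)=O)C(c3cccc(OC)c3OC)O2)cc(OC)c1OC` gives 17.5% in a functional assay on BGC-823 cells (Homo sapiens) for antiproliferative activity, read by MTT assay, tested at 5 uM; a lower number here means a weaker effect, a higher number a stronger effect of the compound at the concentration tested; compound 2 `COc1cc(C2=NN(C(C)=O)C(c3ccc(F)cc3)O2)cc(OC)c1OC` gives 13.3%; compound 3 `COc1cc(C2=NN(C(C)=O)C(c3ccc(Cl)c(Cl)c3)O2)cc(OC)c1OC` gives 3.1%, the lowest of the three, since a number 14.4 percentage points lower from compound 1 to compound 3 (beyond the scatter) and a number 10.2 percentage points lower from compound 2 to compound 3 (beyond the scatter) both lie beyond the scatter, while a number 4.2 percentage points lower from compound 1 to compound 2 (within the scatter) stays within it. Compound 4 `COc1cc(C2=NN(C(C)=O)C(c3ccc(F)c(F)c3)O2)cc(OC)c1OC` is the next step: 3,4-difluorophenyl in place of 3,4-dichlorophenyl on a saturated ring carbon. For the measured compounds named here, the steps that bear on it are the two ending at the 3,4-dichlorophenyl compound, both modest drops, and the one showing 4-fluorophenyl close to 2,3-dimethoxyphenyl. A modest rise is therefore expected, a number 6.9 percentage points higher from compound 3 to compound 4 (within the scatter). Compound 4 is estimated at 10%, within 2% to 20%.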

Compound 4, a percentage reported as inhibition, at one concentration (the size of the read-out at that concentration, not a potency): 21.6%
For compound 4 the middle estimate is 11.6 percentage points below the measured one, and the stated range ends below it.
By their numbers in this assay, from the lowest: compound 3; then compounds 2, 1 and 4 (each within the scatter of the next).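

With the ring pattern kept as 3,4-disubstituted, the choice of halogen counts in this assay, where the change gives a number 18.5 percentage points higher from compound 3 to compound 4 (beyond the scatter). The added fluoro is a smaller matter, with a number 8.3 percentage points higher from compound 2 to compound 4 (within the scatter), and the 3,4-difluorophenyl and 2,3-dimethoxyphenyl groups also stay close, with a number 4.1 percentage points higher from compound 1 to compound 4 (within the scatter). Nothing available explains why the two halogens differ. Still open, on these data alone, is how a 4-chlorophenyl group would compare with the 4-fluorophenyl group, and whether an amine or a carboxylic acid on the phenyl ring would change the read-out at this position.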